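From a Fluorophenyl to a Trimethoxyphenyl Benzyl Triazole

The source may report more compounds than this note shows. Statements on the series, on what has been measured and on what is new or still open speak of the compounds shown alone.

Measured compounds:
compound 1 `Cc1cc(=O)oc2cc(OCCn3cc(CSC(=S)N4CCN(C(=O)OC(C)(C)C)CC4)nn3)ccc12` — 76900 nM
compound 2 `O=C(OCc1ccccc1)N1CCN(C(=S)SCc2cn(Cc3ccc(F)cc3)nn2)CC1` — 17600 nM
compound 3 `Cc1ccc(-n2cc(CSC(=S)N3CCN(C(=O)OC(C)(C)C)CC3)nn2)cc1` — 48300 nM

All three were tested in a functional assay on MGC-803 cells (Homo sapiens) for inhibition, read by MTT assay, with a stated time of 72 h; on this read-out higher numbers stand for weaker inhibition and lower numbers for stronger inhibition. Among them compound 2 stands lowest; its gaps to compound 3 and to compound 1 both lie beyond the scatter, so it is the strongest inhibitor of the three.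

Compound 4 `COc1cc(Cn2cc(CSC(=S)N3CCN(C(=O)OCc4ccccc4)CC3)nn2)cc(OC)c1OC` differs from compound 2 in one place: 3,4,5-trimethoxyphenyl in place of 4-fluorophenyl on a saturated chain carbon bound to an aromatic nitrogen. Among the compounds with values here, no pair of measured compounds shows this change, so nothing in the data tells its size or direction. The expectation therefore rests on compound 2 alone, and a step from compound 2 to compound 4 of about a 1.4-fold lower number from compound 2 to compound 4 (0.13 log units; within the scatter) is estimated, which is within the scatter. Compound 4 is expected to give 13000 nM, with a range from 4000 nM to 40000 nM.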

Compound 4, half-maximal inhibitory concentration: 10900 nM
Compound 4: middle estimate off by 1.2-fold (0.08 log units), on the high side, within the range that was stated.
By their numbers in this assay, from the lowest: compounds 4 and 2 (each within the scatter of the next); then compounds 3 and 1 (each within the scatter of the next).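

In this assay, putting 3,4,5-trimethoxyphenyl in place of 4-fluorophenyl on a saturated chain carbon bound to an aromatic nitrogen gives a 1.6-fold lower number from compound 2 to compound 4 (0.21 log units; within the scatter). Within the data shown here, this is the first measured change at this place, and it shows that the two groups cannot be told apart here, although the entering group carries more heavy atoms and hydrogen-bond acceptors. Nothing measured accounts for this result. As far as these compounds go, whether an amine or a carboxylic acid on the phenyl ring, or a longer chain at this place, would shift the number beyond the scatter stays open.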